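From carboxy to a longer ester chain

The source may hold more compounds than are shown below. What is called first, only, known or untested is meant among the compounds shown, and "the series" means these compounds.

- compound 1 `CCOC(=O)Cn1c(=O)c(-c2ccc(OC)cc2)cc2c(OC)cc(OC)cc21` gives 10000 nM
- compound 2 `COc1ccc(-c2cc3c(OC)cc(OC)cc3n(CCCC#N)c2=O)cc1` gives 10000 nM
- compound 3 `COc1ccc(-c2cc3c(OC)cc(OC)cc3n(CC(=O)O)c2=O)cc1` gives 10000 nM

In a functional assay on LoVo cells (Homo sapiens) for cytotoxicity, read by colorimetric assay and MTT assay (on this read-out higher numbers stand for weaker inhibition and lower numbers for stronger inhibition), compound 3 stands level with the other two at 10000 nM with no gap between them. Compound 4 `COC(=O)CCn1c(=O)c(-c2ccc(OC)cc2)cc2c(OC)cc(OC)cc21` departs from compound 3 by (methoxycarbonyl)methyl in place of carboxy on a saturated chain carbon bound to an aromatic nitrogen and the same difference reads carboxymethyl to 2-(methoxycarbonyl)ethyl. Three measured steps on that chain bear on it, namely no change at the digits printed from compound 1 to compound 3 (within the scatter) with no change at the digits printed from compound 2 to compound 3 (within the scatter) and no change at the digits printed from compound 1 to compound 2 (within the scatter) as well. None of them moved the value, so no step beyond the scatter is expected in this assay here. Going by the values given here, no measured compound carries the 2-(methoxycarbonyl)ethyl chain itself, so the range stays wide. The expected step is no change at the digits printed from compound 3 to compound 4 (within the scatter) as an estimate only. For compound 4 the estimated value is 10000 nM within an expected range of 4000 nM to 20000 nM on this read-out.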

Compound 4, half-maximal inhibitory concentration: 10000 nM
For compound 4 middle estimate and measured number coincide at the digits printed; the measured number falls inside the stated range.
By their numbers in this assay, from the lowest: compounds 1, 2, 3 and 4 (each within the scatter of the next).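

In this assay the change from carboxy to (methoxycarbonyl)methyl gives no change at the digits printed from compound 3 to compound 4 (within the scatter) even though the entering group has no hydrogen-bond donor. The other two chains on this position read the same against the new ester, with no change at the digits printed from compound 1 to compound 4 (within the scatter) and no change at the digits printed from compound 2 to compound 4 (within the scatter) as the printed steps. No measurement here offers an explanation for this flat reading. From the compounds shown here alone, whether a chain ending in a primary amine or a longer alkyl chain would lift activity from this level remains open.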